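The source may report more compounds than this note shows. Statements on the series, on what has been measured and on what is new or still open speak of the compounds shown alone.

Measured compounds:
compound 1, `CCCCCCNc1[nH]ccc2ncnc1-2` — 100%
compound 2, `OC[C@H]1OC(n2cnc3c(NCc4ccccc4)nccc32)[C@H](O)[C@@H]1O` — 5%

In a functional assay on EL4 cells (Mus musculus) for inhibition, tested at 100 uM (a lower number here means less inhibition, a higher number more inhibition at the concentration tested (going by the name of the read-out)), compound 1 gives 100%, whereas compound 2 gives 5%. Going by the values given here, compound 2 therefore holds the lower of the two numbers; its only neighbour, compound 1, sits far higher, by a gap well beyond the scatter of repeated measurements. The two compounds differ in more than one place, so their values show only that the two ends of this small set lie far apart, not which feature carries the difference.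

Compound 3, `CNc1nccc2c1ncn2C1O[C@H](CO)[C@@H](O)[C@H]1O`, is reached from compound 2 by a single change: hydrogen in place of phenyl on a saturated chain carbon bound to a nitrogen on an aromatic ring. The amine bound to the aromatic ring is kept, and the sugar is kept. Among the compounds with values here, no measured pair speaks directly to this change, so the expectation rests on compound 2 alone, which already stands at the low end of the scale in this assay with 5%. From that starting point, the step from compound 2 to compound 3 is expected to be small, a number 3 percentage points higher from compound 2 to compound 3 (within the scatter), and not clearly beyond the scatter in either direction. Compound 3 is accordingly estimated at 8% in this assay, within a range of 0% to 30%.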

Compound 3, a percentage reported as inhibition, at one concentration (the size of the read-out at that concentration, not a potency): 11%
The estimate for compound 3 lay 3 percentage points below the measured number, and the stated range covers the measured number.
By their numbers in this assay, from the lowest: compounds 2 and 3 (each within the scatter of the next); then compound 1.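

With the sugar and the amine bound to the aromatic ring kept, benzylamino gives way to methylamino, and this assay records a number 6 percentage points higher from compound 2 to compound 3 (within the scatter) for this exchange of hydrogen for phenyl on a saturated chain carbon bound to a nitrogen on an aromatic ring. Going by these compounds alone, this is the first direct reading at this position, and it shows that, in this sugar-bearing pair, removing the phenyl with its 6 heavy atoms does not shift the number beyond the scatter. Nothing available gives a measured reason for this outcome.

As far as these compounds go, the result covers only the two ends of this exchange, so it remains open how a cyclohexyl ring, a carboxylic acid or an ethyl group would read at the same place on the sugar-bearing compounds. From the compounds shown here alone, it also remains open what separates these compounds from compound 1 at 100%, as compound 1 differs from each of them in more than one place and its value cannot be assigned to either its hexyl chain or its lack of the sugar.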